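This account rests on a few compounds, and the source may have more. Where it says the series, first, only, none or still open, it means among the compounds named here.

In an assay (Rattus norvegicus) for inhibition of Fatty-acid amide hydrolase 1 (Homo sapiens) (a lower number here means a stronger inhibitor, a higher number a weaker inhibitor), compound 3 `COc1ccnc(-c2cnc(C(=O)CCCCCCc3ccccc3)o2)c1` gives 0.8 nM, the second highest of the three numbers measured. Compound 2 `Cc1ccnc(-c2cnc(C(=O)CCCCCCc3ccccc3)o2)c1` gives 0.6 nM, and a 1.3-fold higher number from compound 2 to compound 3 (0.12 log units; within the scatter). Compound 1 `O=C(O)c1ccc(-c2cnc(C(=O)CCCCCCc3ccccc3)o2)cc1` gives 60 nM, and a 75-fold lower number from compound 1 to compound 3 (1.88 log units; beyond the scatter). Compound 4 `O=C(CCCCCCc1ccccc1)c1ncc(-c2cc(C(F)(F)F)ccn2)o1` carries trifluoromethyl in place of methoxy on an aromatic carbon. The large swings seen so far came from exchanging the whole ring: a 100-fold lower number from compound 1 to compound 2 (2.00 log units; beyond the scatter) and a 75-fold lower number from compound 1 to compound 3 (1.88 log units; beyond the scatter). Going by the values given here, the only swap of a small group on this ring, a 1.3-fold higher number from compound 2 to compound 3 (0.12 log units; within the scatter), stayed within the scatter, and that step bears most directly on compound 4. No step beyond the scatter is therefore expected in this assay. Compound 4 is expected to give 1.2 nM, with a range from 0.4 nM to 4 nM. That estimate means a 1.5-fold higher number from compound 3 to compound 4 (0.18 log units; within the scatter).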

Compound 4, inhibition constant: 3.5 nM
Estimate against measurement, compound 4: 2.9-fold (0.46 log units) below; measured number inside the range.
By their numbers in this assay, from the lowest: compounds 2 and 3 (each within the scatter of the next); then compound 4; then compound 1.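

In this assay, the group opposite the ring nitrogen does make a difference: methyl and methoxy could not be told apart, but trifluoromethyl gives a 4.4-fold higher number from compound 3 to compound 4 (0.64 log units; beyond the scatter) and a 5.8-fold higher number from compound 2 to compound 4 (0.77 log units; beyond the scatter) as the two new steps. This position therefore accepts a small group without a collapse in binding, yet it is not indifferent to which group sits there. No measurement here explains why trifluoromethyl gives the higher number.

From the compounds shown here alone, whether an amine, a nitrile or an ethyl group at this position would stay with methyl and methoxy or move the number further remains open.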